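This account rests on a few compounds, and the source may have more. Where it says the series, first, only, none or still open, it means among the compounds named here.

In a functional assay on LNCaP cells (Homo sapiens) for cytotoxicity (on this read-out lower numbers stand for an effect already at smaller amounts and higher numbers for an effect only at larger amounts of compound), compound 2 `CCC[C@@H](OC(C)=O)C1=C(Br)[C@@](OC)(C(Br)Br)OC1=O` gives 3.6 ug/mL, which is the second highest of the three numbers in hand. Compound 3 `CCC[C@@H](OC(C)=O)C1=C(Br)[C@](OC)(C(Br)Br)OC1=O` gives 4.5 ug/mL, and compound 1 `CCC[C@@H](OC(C)=O)C1=C(Br)[C@@](C)(OC)OC1=O` gives 1.7 ug/mL. Between compound 2 and compound 3 the gap is small: a 1.3-fold higher number from compound 2 to compound 3 (0.10 log units; within the scatter). That closeness is consistent with the fact that compounds 2 and 3 differ only in the configuration as drawn. Between compound 1 and compound 3 the change is larger: a 2.6-fold higher number from compound 1 to compound 3 (0.42 log units; beyond the scatter).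

Compound 4 `CCC[C@@H](OC(C)=O)C1=C(Br)[C@](C)(OC)OC1=O` has not yet been measured in this assay. Set against compound 2, its structure shows one change: methyl in place of dibromomethyl on a saturated ring carbon. The measured step that bears on this change is a 2.6-fold higher number from compound 1 to compound 3 (0.42 log units; beyond the scatter), which carries the same exchange of groups in the opposite direction and moved the number by a modest amount beyond the scatter. The step of a 1.3-fold higher number from compound 2 to compound 3 (0.10 log units; within the scatter) adds that the drawn configuration at this saturated ring carbon by itself shifted the number only within the scatter. On that basis a modest fall in the number is expected when methyl stands in place of dibromomethyl, roughly undoing the earlier rise, so that the expected step is a 2.4-fold lower number from compound 2 to compound 4 (0.38 log units; beyond the scatter). For compound 4 the estimated value in this assay is therefore 1.5 ug/mL, with a range from 0.7 ug/mL to 3.2 ug/mL.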

Compound 4, concentration for half-maximal effect: 3.6 ug/mL
Compound 4: middle estimate off by 2.4-fold (0.38 log units), on the low side, outside the stated range (above it).
By their numbers in this assay, from the lowest: compound 1; then compounds 2, 4 and 3 (each within the scatter of the next).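

In this assay the methyl pair shows what the dibromomethyl pair did not: a change of drawn configuration at this saturated ring carbon can by itself move the number, here with a 2.1-fold higher number from compound 1 to compound 4 (0.33 log units; beyond the scatter), and nothing else separates the two structures: the fact that compounds 1 and 4 differ only in the configuration as drawn. Methyl in place of dibromomethyl gives no change at the digits printed from compound 2 to compound 4 (within the scatter), so in this configuration dibromomethyl can give way to methyl with no visible shift on this read-out. Set beside the earlier step, the exchange does not read as one fixed effect in both configurations, although the two steps cannot be firmly told apart: the same change on two cores in this assay, a 2.6-fold higher number (0.42 log units; beyond the scatter) from compound 1 to compound 3 and no change at the digits printed (within the scatter) from compound 4 to compound 2, 2.6-fold (0.42 log units) apart, within the scatter of two such steps.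

The compounds shown leave open how other groups on this ring carbon, such as ethyl, hydroxymethyl or aminomethyl, would behave in either configuration. They also leave open whether a monobromomethyl group would follow methyl, with its configuration step beyond the scatter, or dibromomethyl, with its configuration step within it.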